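Hydroxy to Amino Swap Across Two Related Cores

The source may report more compounds than this note shows. Statements on the series, on what has been measured and on what is new or still open speak of the compounds shown alone.

Of the compounds shown here, three have been measured in a functional assay on MCF7 cells (Homo sapiens) for antiproliferative activity, read by MTT assay, with a stated time of 48 h; on this read-out lower numbers stand for stronger inhibition and higher numbers for weaker inhibition. Compound 1 `COc1ccc(C(=O)c2ccc(OC)c3c2C=CC(C)(C)O3)c(NC(=O)CO)c1` gives 940 nM, and compound 3 `COc1ccc(C(=O)c2ccc(OC)c3c2C=CC(C)(C)O3)c(NC(=O)CN)c1`, which differs from it by amino in place of hydroxy on a saturated chain carbon bound to a carbonyl carbon, gives 1250 nM. That change produced a 1.3-fold higher number from compound 1 to compound 3 (0.12 log units; within the scatter). Compound 2 `COc1ccc(C(=O)c2ccc3c(c2)C=CC(C)(C)O3)c(NC(=O)CO)c1` gives 200 nM in this assay, the lowest of the three numbers; how its core differs from the core of compound 1 is not broken down here. Compound 4 `COc1ccc(C(=O)c2ccc3c(c2)C=CC(C)(C)O3)c(NC(=O)CN)c1` has not yet been measured. It differs from compound 2 by amino in place of hydroxy on a saturated chain carbon bound to a carbonyl carbon, the same change that turned compound 1 into compound 3, now made on the core of compound 2 rather than on the core of compound 1. The earlier step of a 1.3-fold higher number from compound 1 to compound 3 (0.12 log units; within the scatter) stayed within the scatter. On that basis the expected step in this assay is a 1.3-fold higher number from compound 2 to compound 4 (0.11 log units; within the scatter), a step of similar size, resting on that single earlier instance and on the value of compound 2. Compound 4 is therefore estimated at 260 nM, with a range from 120 nM to 560 nM.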

Compound 4, half-maximal inhibitory concentration: 680 nM
Estimate against measurement, compound 4: 2.6-fold (0.42 log units) below; the measured number lies above the stated range.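

In this assay, amino in place of hydroxy on a saturated chain carbon bound to a carbonyl carbon gave a 3.4-fold higher number from compound 2 to compound 4 (0.53 log units; beyond the scatter) on the core of compound 2, a step beyond the scatter. Set beside the step for the same change on the core of compound 1, this step cannot be told apart from it, so these data give no firm sign that the core alters the size of the change: the same change on two cores in this assay, a 1.3-fold higher number (0.12 log units; within the scatter) from compound 1 to compound 3 and a 3.4-fold higher number (0.53 log units; beyond the scatter) from compound 2 to compound 4, 2.6-fold (0.41 log units) apart, within the scatter of two such steps They do not show that the change carries over at a fixed size either, since there are only two instances, one within the scatter and one beyond it.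

The compounds shown leave open how the same change would read on any further core, and whether a dimethylamino group, a carboxylic acid or a longer chain in place of the hydroxy or amino group would follow the same course. They also leave open which part of the difference between the two cores goes with the lower numbers seen on the core of compound 2.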